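The source may report more compounds than this note shows. Statements on the series, on what has been measured and on what is new or still open speak of the compounds shown alone.

Measured compounds in a functional assay on A549 cells (Homo sapiens) for antiproliferative activity, read by MTT assay, with a stated time of 72 h; on this read-out higher numbers stand for weaker inhibition and lower numbers for stronger inhibition:
- compound 1 `COc1ncc(-c2ccc3c(c2)NC(=O)CO3)cc1NS(=O)(=O)c1ccc(F)cc1`: 8070 nM
- compound 2 `O=C1COc2ccc(-c3cnc(Cl)c(NS(=O)(=O)c4ccc(F)cc4)c3)cc2N1`: a limit, > 40000 nM
- compound 3 `O=C1COc2ccc(-c3cnc4ccccc4c3)cc2N1`: a limit, > 40000 nM

Among the compounds with values here, compound 1 stands as the only outright number among the three; compound 2 and compound 3 each sit at the limit of > 40000 nM in this assay, at which 2 of the 3 values shown sit. Compound 4 `COc1ncc(-c2ccc3c(c2)N(C(C)C)C(=O)CO3)cc1NS(=O)(=O)c1ccc(F)cc1` arises from compound 1 by isopropyl in place of hydrogen on an amide-type nitrogen in a ring. Within the data shown here, the one measured step, an at least 4.9-fold higher number from compound 1 to compound 2 (0.69 log units; beyond the scatter), concerns the methoxy group and not the amide-type nitrogen in the ring, so it does not bear on this change; no measured step touches that nitrogen. With no direct guide, compound 4 is expected to show a 2.0-fold higher number from compound 1 to compound 4 (0.30 log units; within the scatter), a modest weakening at most. Compound 4 is therefore estimated at 16000 nM, in the range 4000 nM to 40000 nM, with a fair chance that this assay returns only a limit.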

Compound 4, half-maximal inhibitory concentration: 4920 nM
Estimate against measurement, compound 4: 3.3-fold (0.51 log units) above; the measured number falls inside the stated range.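

In this assay the amide-type nitrogen in the ring, untouched by any earlier measured step, carries isopropyl in place of hydrogen with a 1.6-fold lower number from compound 1 to compound 4 (0.21 log units; within the scatter) and so the amide hydrogen is not needed to hold the level of compound 1. Within the data shown here, compound 2 and compound 3 remain the only compounds at a limit, and compound 4 does not join them: the limit of > 40000 nM in this assay, at which 2 of the 4 values shown sit.

On these data alone, whether a longer chain, an amine or a carboxylic acid on this nitrogen would hold that level stays open. So does whether isopropyl would behave alike with chloro in place of methoxy.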